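Fluoro on the benzoyl ring: stability notes

The source may report more compounds than this note shows. Statements on the series, on what has been measured and on what is new or still open speak of the compounds shown alone.

Compound 1 `Fc1ccc(CN2CCC(NCCSC(c3ccc(F)cc3)c3ccc(F)cc3)CC2)cc1` and compound 2 `O=C(c1ccccc1)N1CCC(NCCSC(c2ccc(F)cc2)c2ccc(F)cc2)CC1` stand level at the top of the read-out: in an ADME assay on microsomes from liver (Rattus norvegicus) for metabolic stability, read by LC-MS, using NADPH, tested at 10 uM (on this read-out higher numbers stand for a more stable compound and lower numbers for a less stable compound), compound 1 gives 100%, and compound 2 gives 100%. Among the compounds with values here, the single measured step, no change at the digits printed from compound 1 to compound 2 (within the scatter), shows that exchanging the group on the ring nitrogen left this assay untouched. Compound 3 `O=C(c1ccc(F)cc1)N1CCC(NCCSC(c2ccc(F)cc2)c2ccc(F)cc2)CC1` differs from compound 2 by fluoro in place of hydrogen on an aromatic carbon. Within the data shown here, no measured step tests this change directly. Among the measured compounds shown here, since the one step available shows a larger exchange without effect, no movement beyond the scatter is expected, a number 3 percentage points lower from compound 2 to compound 3 (within the scatter). Compound 3 is therefore expected to give 97%, between 85% and 100%.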

Compound 3, percent of the compound remaining: 100%
Beside the measured number, compound 3's estimate is 3 percentage points below it; the measured number falls inside the stated range.
By their numbers in this assay, from the lowest: compounds 1, 2 and 3 (each within the scatter of the next).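

In this assay, fluoro in place of hydrogen on the aromatic carbon para to a large group reads as no change at the digits printed from compound 2 to compound 3 (within the scatter), so this position of the benzoyl ring accepts the added fluorine with no visible cost. Taken together with the exchange on the ring nitrogen, (4-fluorophenyl)carbonyl for 4-fluorobenzyl reads as no change at the digits printed from compound 1 to compound 3 (within the scatter). No independent evidence bears on this result.

On these data alone, whether a carboxylic acid or a dimethylamino group in place of fluoro at this position would shift the number remains open. So does whether any change to the shared core would.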